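Notes on the step from compound 2 to compound 3

A few compounds are considered here, and "the series" means these few. Any claim that something is new, unique, unknown or untested is made for them only; others in the source may bear on it.

Values measured in a functional assay on SMMC-7721 cells (Homo sapiens) for antiproliferative activity, read by MTT assay, with a stated time of 48 h (on this read-out higher numbers stand for weaker inhibition and lower numbers for stronger inhibition), so far
- compound 1 `Cn1cc(C2=C(c3nn(CCCn4cncn4)c4ncccc34)C(=O)N(c3ccccc3)C2=O)c2ccccc21` gives > 100000 nM as a limit of the assay
- compound 2 `Cn1cc(C2=C(c3nn(CCCn4ccnc4)c4ncccc34)C(=O)N(c3ccccc3)C2=O)c2ccccc21` gives 34800 nM as a measured number

Among the measured compounds shown here, compound 2 holds the only true number, since the other entry is only a limit. Compound 3 `CN(C)CCCn1nc(C2=C(c3cn(C)c4ccccc34)C(=O)N(c3ccccc3)C2=O)c2cccnc21` carries the change dimethylamino in place of 1H-imidazol-1-yl on a saturated chain carbon, three bonds along the chain from an aromatic nitrogen and so has dimethylamino in place of 1H-imidazol-1-yl on a saturated chain carbon, three bonds along the chain from an aromatic nitrogen. For the measured compounds named here, one measured step bears on this, at the same place. Going by the values given here, from the size of an at least 2.8-fold lower number from compound 1 to compound 2 (0.45 log units; beyond the scatter) in that exchange, a modest step towards a lower number is expected in this assay for the new group, though no measured compound carries dimethylamino. The expected step is a 2.3-fold lower number from compound 2 to compound 3 (0.37 log units; beyond the scatter) on this estimate. The estimated value for compound 3 is 15000 nM with a wide expected range (3000 nM to 70000 nM).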

Compound 3, half-maximal inhibitory concentration: 31200 nM
Compound 3: middle estimate off by 2.1-fold (0.32 log units), on the low side; the range from low to high includes it.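

In this assay, dimethylamino at this place gives a 1.1-fold lower number from compound 2 to compound 3 (0.05 log units; within the scatter), so among the compounds shown an open-chain group with no ring serves on the saturated chain carbon as well as 1H-imidazol-1-yl does. Against 1H-1,2,4-triazol-1-yl the new group gives an at least 3.2-fold lower number from compound 1 to compound 3 (0.50 log units; beyond the scatter), which matches the earlier step from that group to 1H-imidazol-1-yl and leaves compound 1 apart from compound 2 and compound 3. Compound 1 stands at a limit of the assay, so both steps from it are bounds and not sizes: the limit of > 100000 nM in this assay, at which 1 of the 3 values shown sits.

As far as these compounds go, whether a cyclic amine such as morpholine or piperidine in place of dimethylamino moves the number beyond the scatter stays open. So does the effect of a longer chain than 3-(dimethylamino)propyl, since every compound here carries the same chain length.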